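Lengthening the chain of a urea-based acyltransferase inhibitor

The source may hold more compounds than are shown below. What is called first, only, known or untested is meant among the compounds shown, and "the series" means these compounds.

Compound 1: `CCCCCCCC/C=C\CCCCCCCCNC(=O)Nc1c(Cl)cc(Cl)cc1Cl` with 1200 nM
Compound 2: `CCCCCCCCCCCCCCNC(=O)Nc1ccc(F)cc1F` with 340 nM
Compound 3: `CCCCCCCCCC(C)(C)CNC(=O)Nc1c(C(C)C)cccc1C(C)C` with 46 nM

All three are ureas carrying a long saturated or unsaturated chain on one nitrogen and an aromatic ring on the other. They were tested in an assay on microsomes from intestinal mucosa for inhibition of acyl-CoA:cholesterol acyltransferase (Oryctolagus cuniculus); a lower number here means a stronger inhibitor, a higher number a weaker inhibitor. Compound 3 has the lowest number of the three, so it is the strongest inhibitor among them; compound 2 sits a good way above it, and compound 1 further still, both gaps well beyond the usual scatter.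

Compound 4 is `CCCCCCCCCCC(C)(C)CNC(=O)Nc1c(C(C)C)cccc1C(C)C`. It differs from compound 3 in one spot: methyl in place of hydrogen on a saturated chain carbon, ten or more bonds along the chain from an amide-type nitrogen. The chain grows by a single carbon at its far end, while the urea and the aromatic ring stay as they are. Within the data shown here, no measured pair in this set shows what such an addition does, so there is no step to lean on. A change this small and this remote from the urea would be expected to shift the number little, and in a 1.2-fold lower number from compound 3 to compound 4 (0.06 log units; within the scatter) expected here the step from compound 3 to compound 4 is estimated to stay within the scatter. For compound 4 the value in this assay is estimated at 40 nM, with a range from 15 nM to 120 nM.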

Compound 4, half-maximal inhibitory concentration: 47 nM
Beside the measured number, compound 4's estimate is 1.2-fold (0.07 log units) below it; measured number inside the range.
By their numbers in this assay, from the lowest: compounds 3 and 4 (each within the scatter of the next); then compound 2; then compound 1.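

Among these compounds, this pair is the first in the set to differ in one place, so it gives the first direct reading of the far end of the chain. In this assay the change, methyl in place of hydrogen on a saturated chain carbon, ten or more bonds along the chain from an amide-type nitrogen, gives a 1.0-fold higher number from compound 3 to compound 4 (0.01 log units; within the scatter) and lies within the scatter, so the two numbers cannot be told apart. Nothing on hand speaks to why this is so.

This is only one small step, so the compounds shown do not tell how much further the chain could grow with the same outcome. As far as these compounds go, what a much longer chain, or a carboxylic acid or an amine at the chain's far end, would do to the number also remains open.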